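Azocane replacing the dimethylanilino group in the TRPV1 series

A few compounds are considered here, and "the series" means these few. Any claim that something is new, unique, unknown or untested is made for them only; others in the source may bear on it.

Working notes on the series. Compound 1 `Cc1ccc(Nc2nc(C(F)(F)F)ccc2CNC(=O)C(C)c2ccc(NS(C)(=O)=O)c(F)c2)cc1C` is measured in a functional assay on CHO-K1 cells for antagonist activity at transient receptor potential cation channel subfamily V member 1 (Homo sapiens), read by FLIPR (a lower number here means a stronger inhibitor, a higher number a weaker inhibitor), where compound 1 gives 39.3 nM. Within the data shown here, this is the highest of the two numbers recorded; the only other measured member, compound 2 `C[C@H](C(=O)NCc1ccc(C(F)(F)F)nc1N1CC[C@@H](OCc2ccccc2)C1)c1ccc(NS(C)(=O)=O)c(F)c1`, gives 1.4 nM in this assay, a gap well beyond the scatter. Compound 3 `CC(C(=O)NCc1ccc(C(F)(F)F)nc1N1CCCCCCC1)c1ccc(NS(C)(=O)=O)c(F)c1` has not been measured. It differs from compound 1 at one place: a group of 8 heavy atoms (7 carbon, 1 nitrogen; one eight-membered non-aromatic ring with 1 hetero atom) in place of a group of 9 heavy atoms (8 carbon, 1 nitrogen; one six-membered aromatic ring of carbon only), on an aromatic carbon. Among the measured compounds shown here, no step between measured compounds shares this change, so the direction of this assay for compound 3 is open. The number for compound 1 sits far above that of compound 2, which suggests the shared core can reach much lower numbers. An improvement, beyond the scatter, is expected for compound 3, the step of a 3.9-fold lower number from compound 1 to compound 3 (0.59 log units; beyond the scatter) being the estimate. In this assay compound 3 is expected at 10 nM, within 2 nM to 60 nM.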

Compound 3, inhibition constant: 0.7 nM
For compound 3 the middle estimate is 14-fold (1.15 log units) above the measured one, outside the stated range (below it).
By their numbers in this assay, from the lowest: compounds 3 and 2 (each within the scatter of the next); then compound 1.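

At the aromatic carbon next to the ring nitrogen, replacing (3,4-dimethylphenyl)amino with the eight-membered non-aromatic ring gives in this assay a step of a 56-fold lower number from compound 1 to compound 3 (1.75 log units; beyond the scatter) and is large. A low number at this position therefore requires neither the six-membered aromatic ring nor the hydrogen-bond donor of the departing group, since compound 3 has neither of them there. No available data explain the size of this step.

This single step removes the aromatic ring and the donor together, so their separate contributions remain unresolved, and an N-methyl-N-(3,4-dimethylphenyl)amino group would keep the ring without the donor. From the compounds shown here alone, how the number depends on ring size at this position also stays open, with piperidine and azepane as the obvious smaller rings to compare.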